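This account rests on a few compounds, and the source may have more. Where it says the series, first, only, none or still open, it means among the compounds named here.

Of the compounds shown here, two built on a shared core have so far been measured in an assay on isolated protein for inhibition of Leucine-rich repeat serine/threonine-protein kinase 2 (Homo sapiens), read by TR-FRET and LanthaScreen, with stated times of 50 min and 30 min, in the presence of a further agent that is not named here; a higher number here means a weaker inhibitor, a lower number a stronger inhibitor. Compound 1 `Cc1c(Nc2nc(N)c3c(C#N)c(N4CCC[C@H]4C)n(C)c3n2)cnn1CC(C)(C)O` gives 43 nM. Compound 2 `Cc1c(Nc2nc(N)c3c(C#N)c(N4CCC[C@H]4C)n(C)c3n2)cnn1C1COC1` gives 47 nM. Among the measured compounds shown here, the single step between them, a 1.1-fold higher number from compound 1 to compound 2 (0.04 log units; within the scatter), shows that exchanging the group on the aromatic nitrogen left the inhibition essentially where it was. Among the two numbers available, that of compound 2 sits alongside that of compound 1, the pair lying within the usual scatter of each other, so neither can be called the stronger inhibitor.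

Compound 3 `Cc1c(Nc2nc(N)c3c(C#N)c(N4CCC[C@H]4C)n(C)c3n2)cnn1[C@H]1CCOC1` has not yet been measured. It differs from compound 2 in one place: oxolan-3-yl in place of oxetan-3-yl on an aromatic nitrogen. For the measured compounds named here, the only measured step that bears on this position is the one from compound 1 to compound 2, which stayed within the scatter and suggests that this spot tolerates a change from a chain to a small ring. Because of a 1.1-fold higher number from compound 1 to compound 2 (0.04 log units; within the scatter), little movement in this assay is expected when the four-membered ring becomes a five-membered one. For compound 3 the expected step is a 1.0-fold lower number from compound 2 to compound 3 (0.02 log units; within the scatter). Compound 3 is therefore estimated at 45 nM, with a likely range from 20 nM to 110 nM.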

Compound 3, half-maximal inhibitory concentration: 23 nM
Beside the measured number, compound 3's estimate is 2.0-fold (0.29 log units) above it; measured number inside the range.
By their numbers in this assay, from the lowest: compounds 3, 1 and 2 (each within the scatter of the next, the first and the last beyond it).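

In this assay, among the compounds shown here, oxolan-3-yl in place of oxetan-3-yl on the aromatic nitrogen gives a 2.0-fold lower number from compound 2 to compound 3 (0.31 log units; beyond the scatter) and this modest step is the first at this position to lie beyond the scatter, so the spot that seemed indifferent to the earlier exchange does respond when a four-membered ring becomes a five-membered one. The comparison with the open chain is less decisive: oxolan-3-yl in place of 2-hydroxy-2-methylpropyl gives a 1.9-fold lower number from compound 1 to compound 3 (0.27 log units; within the scatter) and that step stays within the scatter, which means compound 1 and compound 3 cannot be ranked against each other, and only the two ring compounds are separated. No measurement at hand accounts for the difference between the two rings.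

The compounds shown leave open whether the change carries on to a six-membered ring such as oxan-4-yl, or what happens when the ring oxygen gives way to an amine, as in piperidin-4-yl. They also leave open how the mirror-image form of oxolan-3-yl, with the opposite arrangement at its defined stereocentre, would compare with compound 3.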